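Lengthening the propylamino chain from propyl to butyl

A few compounds are considered here, and "the series" means these few. Any claim that something is new, unique, unknown or untested is made for them only; others in the source may bear on it.

Measured so far in a functional assay on the whole organism with Rattus norvegicus as the target; a lower number here means that less compound is needed, a higher number that more compound is needed for the effect
compound 1 `CCOC(=O)C(=O)Nc1cccc(OC)c1C#N` gives 5.3 mg/kg
compound 2 `CCOC(=O)C(=O)Nc1cccc(N)c1C#N` gives 0.05 mg/kg
compound 3 `CCCNc1cccc(NC(=O)C(=O)OCC)c1C#N` gives 0.5 mg/kg

Compound 3 stands second highest of the three numbers, with compound 2 as its nearest neighbour and compound 1 furthest away. Compound 4 `CCCCNc1cccc(NC(=O)C(=O)OCC)c1C#N` carries methyl in place of hydrogen on a saturated chain carbon, three bonds along the chain from a nitrogen on an aromatic ring so that propyl becomes butyl.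

The closest measured evidence is a 10-fold higher number from compound 2 to compound 3 (1.00 log units; beyond the scatter) where propyl replaces hydrogen on the same nitrogen. The other two steps replace methoxy and are larger, at a 110-fold lower number from compound 1 to compound 2 (2.03 log units; beyond the scatter) and an 11-fold lower number from compound 1 to compound 3 (1.03 log units; beyond the scatter) but they say little about chain length. For the measured compounds named here, no measured pair extends an existing chain, so the size of this change in this assay remains untested. Going by the values given here, compound 3 at 0.5 mg/kg is the only alkylated example, and the direction of its step from compound 2 gives a weak lean toward a higher number. The estimated change is a 1.6-fold higher number from compound 3 to compound 4 (0.20 log units; within the scatter) with little expected beyond the scatter. For compound 4 the expected value is 0.8 mg/kg within an estimated range of 0.2 mg/kg to 3 mg/kg on this limited evidence.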

Compound 4, dose for half-maximal effect: 0.3 mg/kg
Estimate against measurement, compound 4: 2.7-fold (0.43 log units) above; the measured number falls inside the stated range.
By their numbers in this assay, from the lowest: compound 2; then compounds 4 and 3 (each within the scatter of the next); then compound 1.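

Propyl to butyl is the first chain extension in this series, and in this assay it reads as a 1.7-fold lower number from compound 3 to compound 4 (0.22 log units; within the scatter) so that these two alkylated amines cannot be told apart on this evidence. The cost of alkylating the free amino group persists with the longer chain, at a 6.0-fold higher number from compound 2 to compound 4 (0.78 log units; beyond the scatter) in the same direction as a 10-fold higher number from compound 2 to compound 3 (1.00 log units; beyond the scatter) and beyond the scatter in both cases, while the methoxy comparison also holds with butylamino, at an 18-fold lower number from compound 1 to compound 4 (1.25 log units; beyond the scatter) on the same side as the propylamino compound. No supporting evidence bears on this result.

The compounds shown leave open whether the flat reading from propyl to butyl continues to a longer chain such as hexyl or octyl, and whether methyl or ethyl on the same nitrogen would lie closer to compound 2 or to compound 3. Also open, as far as these compounds go, is how a branched group such as isopropyl, a second alkyl group on that nitrogen, or a carboxylic acid in place of the ethyl ester would read in this assay on this core.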